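Pyrimidin-2-yl in Place of Pyrazin-2-yl: An Expected Step

A few compounds are considered here, and "the series" means these few. Any claim that something is new, unique, unknown or untested is made for them only; others in the source may bear on it.

Compound 1, `CCC(=O)c1ccc(OCCCN2CCN(c3ncccn3)CC2)cc1`, gives 36.9 nM in a functional assay on L5178Y cells (Mus musculus) for antiproliferative activity, read by MTT assay; on this read-out lower numbers stand for stronger inhibition and higher numbers for weaker inhibition.
Compound 2, `CCC(=O)c1ccc(OCCCN2CCN(c3cnccn3)CC2)cc1`, gives 24.3 nM in this assay.
Compound 3, `CCC(C)(C)c1ccc(OCCCCN2CCN(c3cnccn3)CC2)cc1`, gives 9.56 nM in this assay.

The change pyrimidin-2-yl in place of pyrazin-2-yl on an amine nitrogen in a ring gave a 1.5-fold higher number from compound 2 to compound 1 (0.18 log units; within the scatter). Compound 3 has the lowest number of the three; the difference between its core and that of compound 2 is not broken down here. Compound 4, `CCC(C)(C)c1ccc(OCCCCN2CCN(c3ncccn3)CC2)cc1`, carries the same change, (pyrimidin-2-yl in place of pyrazin-2-yl on an amine nitrogen in a ring), on the core of compound 3. Because the earlier change gave a 1.5-fold higher number from compound 2 to compound 1 (0.18 log units; within the scatter), the step from compound 3 to compound 4 is expected to be of like size, a 1.5-fold higher number from compound 3 to compound 4 (0.17 log units; within the scatter), resting on that single earlier pair alone. Compound 4 is therefore estimated at 14 nM in this assay, between 7 nM and 30 nM.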

Compound 4, half-maximal inhibitory concentration: 17.7 nM
Compound 4: the middle estimate sits 1.3-fold (0.10 log units) below what was measured; low and high end bracket the measured number.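

In this assay pyrimidin-2-yl in place of pyrazin-2-yl on an amine nitrogen in a ring gave a 1.9-fold higher number from compound 3 to compound 4 (0.27 log units; within the scatter) and this step can be set beside the earlier one on the other core. The two steps do not differ by more than the scatter allows, so the change carried across these two cores without a detectable difference: the same change on two cores in this assay, a 1.5-fold higher number (0.18 log units; within the scatter) from compound 2 to compound 1 and a 1.9-fold higher number (0.27 log units; within the scatter) from compound 3 to compound 4, 1.2-fold (0.09 log units) apart, within the scatter of two such steps. Among the compounds shown here, this rests on only two pairs, each step itself within the scatter, so it does not show that the change truly moves the number, nor that it would behave alike on any further core.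

The compounds shown leave open how other groups on that amine nitrogen, such as pyridin-2-yl or phenyl, would read in this assay and whether the same change would carry to a core with a longer chain.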